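Halogen swap on the benzyl ether of compound 2

The compounds below may be only part of what the source reports. "The series", "measured", "known", "first", "only" and "open" are said of these compounds alone.

For the measured compounds named here, compound 2 `C[C@H]1C=C2C=C[C@H](C)[C@H](CCC3C[C@@H](O)CC(=O)O3)[C@H]2[C@@H](OCc2ccc(Cl)cc2)C1` carries the 4-chlorobenzyl ether; in an assay for inhibition of 3-hydroxy-3-methylglutaryl-coenzyme A reductase (Rattus norvegicus) (on this read-out lower numbers stand for stronger inhibition and higher numbers for weaker inhibition), compound 2 gives 170 nM, the lowest of the two numbers measured so far. Its nearest neighbour is compound 1 `CC(=O)O[C@H]1C[C@@H](C)C=C2C=C[C@H](C)[C@H](CCC3C[C@@H](O)CC(=O)O3)[C@H]21`, which in this assay gives 269 nM; the step of a 1.6-fold lower number from compound 1 to compound 2 (0.20 log units; within the scatter) lies within the scatter, so the two are not separated. Compound 3 `C[C@H]1C=C2C=C[C@H](C)[C@H](CCC3C[C@@H](O)CC(=O)O3)[C@H]2[C@@H](OCc2ccc(F)cc2)C1` differs from compound 2 by fluoro in place of chloro on an aromatic carbon. Going by the values given here, no measured step touches this position: the only step seen so far exchanges acetyl for 4-chlorobenzyl on an oxygen on a saturated carbon and says nothing about the halogen on the ring. Among the compounds with values here, with no bearing step and a change confined to one aromatic substituent, a step no larger than the scatter is expected in this assay, with no direction preferred. Compound 3 is therefore expected to give about 200 nM in this assay, with a range of 80 nM to 500 nM. The expected step is a 1.2-fold higher number from compound 2 to compound 3 (0.07 log units; within the scatter).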

Compound 3, half-maximal inhibitory concentration: 4.7 nM
For compound 3 the middle estimate is 43-fold (1.63 log units) above the measured one; the measured number lies below the stated range.
By their numbers in this assay, from the lowest: compound 3; then compounds 2 and 1 (each within the scatter of the next).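

The halogen on the benzyl ether is not a silent position in this assay: fluoro in place of chloro on the aromatic carbon gives a 36-fold lower number from compound 2 to compound 3 (1.56 log units; beyond the scatter) and so moves the number well beyond the scatter, although no ring, net charge or hydrogen-bond count changes. The exchange of acetyl for a benzyl ether, which did not separate compound 1 from compound 2, now depends on the halogen carried: 4-fluorobenzyl in place of acetyl gives a 57-fold lower number from compound 1 to compound 3 (1.76 log units; beyond the scatter) and is large. Nothing at hand explains why the two halogens differ so widely.

The compounds shown leave open whether fluoro itself sets this level or chloro alone sets the compound back, which a plain benzyl ether or a 4-bromobenzyl ether would help to tell. Going by these compounds, how far the result holds for a methoxy group on the same aromatic carbon also stays open.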